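Swapping nitro for hydroxy on the lactam aryl ring

The source may report more compounds than this note shows. Statements on the series, on what has been measured and on what is new or still open speak of the compounds shown alone.

The study concerns three measured compounds and one that awaits measurement, all sharing a common core. Compound 1 `COc1ccc(N2C(=O)[C@@H](O)[C@@H]2c2cc(OC)c(OC)c(OC)c2)cc1O` gives 406 nM in a functional assay on HuTu80 cells (Homo sapiens) for antiproliferative activity, read by MTT assay, with a stated time of 72 h; on this read-out higher numbers stand for weaker inhibition and lower numbers for stronger inhibition. Compound 2 `COc1ccc([C@@H]2[C@H](O)C(=O)N2c2cc(OC)c(OC)c(OC)c2)cc1[N+](=O)[O-]` gives 529 nM, the higher of the two single numbers, though the gap to compound 1 is within the usual scatter and the two cannot be ordered. Compound 3 `COc1ccc([C@H]2[C@H](O)C(=O)N2c2cc(OC)c(OC)c(OC)c2)cc1O` was measured three times, giving 13.4 nM; 3.05 nM; 590 nM (3 entries), and these entries the several entries of compound 3 in this assay, 13.4 nM; 3.05 nM; 590 nM (3 entries) spread far more widely than repeated measurements usually do, so no single number can be assigned to it.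

Compound 4 `COc1ccc([C@@H]2[C@H](O)C(=O)N2c2cc(OC)c(OC)c(OC)c2)cc1O` has not been measured. It differs from compound 2 as follows: hydroxy in place of nitro on an aromatic carbon. Within the data shown here, no measured pair in the set differs in one place, so there is no measured step to lean on. Compound 1 and compound 3, both hydroxy-bearing, show numbers ranging from the low entries of compound 3 up to values near compound 2. On that basis a decrease in number for compound 4 relative to compound 2 is expected, of moderate size but uncertain. The expected change is a 4.4-fold lower number from compound 2 to compound 4 (0.64 log units; beyond the scatter). The estimate for compound 4 in this assay is 120 nM, with a range from 8 nM to 1500 nM.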

Compound 4, half-maximal inhibitory concentration: 28.8 nM
The estimate for compound 4 lay 4.2-fold (0.62 log units) above the measured number; the range from low to high includes it.
By their numbers in this assay, from the lowest: compound 4; then compounds 1 and 2 (each within the scatter of the next).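

In this assay, among these compounds, hydroxy in place of nitro on an aromatic carbon, ortho to a methoxy group and meta to a large group, gives an 18-fold lower number from compound 2 to compound 4 (1.26 log units; beyond the scatter), the first step in the set that can be read at a single place. It shows that the number depends strongly on which of these two groups sits at this position, something the earlier compounds could not show, although this one step cannot say whether the hydrogen-bond donor that enters with hydroxy, the heavy atoms that leave with nitro or something else accounts for it. Compound 4, at 28.8 nM, also gives a single number to one member of a pair defined by this: the fact that compounds 3 and 4 differ only in the configuration as drawn

On these data alone, what that pair says about configuration stays open, as compound 3 has no single number to set against compound 4: the several entries of compound 3 in this assay, 13.4 nM; 3.05 nM; 590 nM (3 entries) Also open is whether an amine or a carboxylic acid on the same aromatic carbon would give a number closer to that of hydroxy or of nitro, and whether the step would hold on compounds with another configuration.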